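Aminophenyl in Place of Methoxyphenyl: The Next Step

The compounds below may be only part of what the source reports. "The series", "measured", "known", "first", "only" and "open" are said of these compounds alone.

Of the compounds shown here, two sharing a common core have been measured so far. Compound 1 `O=C(CCCCCCc1ccccc1)c1ncc(-c2ccccc2F)o1` gives 110 nM in an assay (Rattus norvegicus) for inhibition of Fatty-acid amide hydrolase 1 (Homo sapiens); a lower number here means a stronger inhibitor, a higher number a weaker inhibitor. Compound 2 `COc1ccccc1-c1cnc(C(=O)CCCCCCc2ccccc2)o1` gives 400 nM in this assay. On these two numbers compound 2 stands highest, and its nearest neighbour is compound 1, whose number is lower by the step of a 3.6-fold higher number from compound 1 to compound 2 (0.56 log units; beyond the scatter); that step came with methoxy in place of fluoro on an aromatic carbon and lies beyond the scatter.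

Compound 3 `Nc1ccc(-c2cnc(C(=O)CCCCCCc3ccccc3)o2)cc1` is not yet measured. It differs from compound 2 by 4-aminophenyl in place of 2-methoxyphenyl on an aromatic carbon. Among the measured compounds shown here, only the single measured step bears on this change, and only loosely: it shows that swapping the substituent on this phenyl ring moved the number by a modest but real amount. For the measured compounds named here, no measured pair contains an amino group, so the direction of the coming step is uncertain. Because compound 1 with its fluoro gave 110 nM and compound 2 gave 400 nM, compound 3 is expected to land between or near those numbers, a step of a 1.6-fold lower number from compound 2 to compound 3 (0.20 log units; within the scatter). The estimate for compound 3 in this assay is 250 nM, with a range from 80 nM to 800 nM.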

Compound 3, inhibition constant: 90 nM
The estimate for compound 3 lay 2.8-fold (0.44 log units) above the measured number, and the stated range covers the measured number.
By their numbers in this assay, from the lowest: compounds 3 and 1 (each within the scatter of the next); then compound 2.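

In this assay the step of a 4.4-fold lower number from compound 2 to compound 3 (0.65 log units; beyond the scatter) shows that the aromatic carbon next to the ring oxygen can take 4-aminophenyl in place of 2-methoxyphenyl and give a clearly lower number, so the substituent on this phenyl ring can move the result in either direction. The step of a 1.2-fold lower number from compound 1 to compound 3 (0.09 log units; within the scatter) leaves 4-aminophenyl and 2-fluorophenyl indistinguishable in this assay, and of the three phenyl groups shown, only 2-methoxyphenyl stands apart from the others. Nothing available here explains why these groups give the numbers they do.

The change from compound 2 to compound 3 alters both the substituent and its place on the phenyl ring, so the compounds shown cannot separate these two changes; 2-aminophenyl and 4-methoxyphenyl would be the groups to tell them apart. On these data alone, it also remains open how an unsubstituted phenyl, a 4-carboxyphenyl or a 4-dimethylaminophenyl would compare with 4-aminophenyl at this position.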